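This account rests on a few compounds, and the source may have more. Where it says the series, first, only, none or still open, it means among the compounds named here.

Measured so far:
compound 1 `Cc1ccc(C(=O)N(C(=S)OCCN2C(=O)c3ccccc3C2=O)c2ccc(Cl)cc2)cc1` — > 100000 nM
compound 2 `Cc1ccc(N(C(=O)c2cccc([N+](=O)[O-])c2)C(=S)OCCN2C(=O)c3ccccc3C2=O)cc1` — 100000 nM

In an ADME assay on MT4 cells (Homo sapiens) for cytotoxicity, read by MTT assay (a higher number here means that more compound is tolerated, a lower number that less compound is tolerated), compound 1 gives > 100000 nM, which is a limit of the assay and not a number. Compound 1 therefore stands at the limit of > 100000 nM in this assay, at which 1 of the 2 values shown sits, with no real value to set a step from. Going by the values given here, compound 2 gives 100000 nM in this assay; both measured compounds thus sit at the top of the range tested, and no step between them can be read.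

Compound 3 `O=C1c2ccccc2C(=O)N1CCOC(=S)N(C(=O)c1ccc(Cl)c(Cl)c1)c1ccc(Cl)cc1` differs from compound 1 by 3,4-dichlorophenyl in place of 4-methylphenyl on a carbonyl carbon. Among the compounds with values here, no measured step of this kind exists, so the expectation rests on the two measured values alone. In this assay any step is expected to be small, if anything toward less tolerated, and most likely within the scatter. For compound 3 the expected value in this assay is estimated at 70000 nM, with a range from 20000 nM to 150000 nM. This estimate means an expected step of an at least 1.4-fold lower number from compound 1 to compound 3 (0.15 log units; that floor lies within the scatter).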

Compound 3, half-maximal cytotoxic concentration: 35000 nM
For compound 3 the middle estimate is 2.0-fold (0.30 log units) above the measured one; the range from low to high includes it.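

Going by these compounds alone, the only readable step so far comes from exchanging the 4-methylphenyl on a carbonyl carbon for 3,4-dichlorophenyl: in this assay, the change gives an at least 2.8-fold lower number from compound 1 to compound 3 (0.45 log units; beyond the scatter). The tolerated concentration therefore responds to the group at this position, which compound 1 and compound 2 alone could not show. Only the minimum size of the step is known, because the value for compound 1 is a limit and not a number: the limit of > 100000 nM in this assay, at which 1 of the 3 values shown sits.

The compounds shown leave open whether the step follows from the two chlorines together, from a single chlorine or from the loss of the methyl. Going by these compounds, it also remains open how this assay would respond to an amine or a carboxylic acid on the phenyl ring attached to this carbonyl carbon.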